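The source may hold more compounds than are shown below. What is called first, only, known or untested is meant among the compounds shown, and "the series" means these compounds.

Measured so far:
- compound 1, `CN(C(=O)NC(=O)c1ccc(Cl)cc1Cl)c1nc(C(F)(F)F)c(C(=O)N/N=C/c2cccc(C(F)(F)F)c2)s1`: 10.6 ug/mL
- compound 2, `CN(C(=O)NC(=O)c1ccc(Cl)cc1Cl)c1nc(C(F)(F)F)c(C(=O)N/N=C/c2ccc(C(F)(F)F)cc2)s1`: 9.4 ug/mL

In a functional assay on A549 cells (Homo sapiens) for inhibition, read by MTT assay, with a stated time of 72 h (on this read-out lower numbers stand for stronger inhibition and higher numbers for weaker inhibition), compound 1 gives 10.6 ug/mL and compound 2 gives 9.4 ug/mL. Compound 2 cannot be separated from compound 1 on these numbers: the move to 4-(trifluoromethyl)phenyl in place of 3-(trifluoromethyl)phenyl on the carbon with a double bond to nitrogen gives a 1.1-fold lower number from compound 1 to compound 2 (0.05 log units; within the scatter).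

Compound 3, `Cc1nc(N(C)C(=O)NC(=O)c2ccc(Cl)cc2Cl)sc1C(=O)N/N=C/c1ccc(C(F)(F)F)cc1`, differs from compound 2 in one place: methyl in place of trifluoromethyl on an aromatic carbon. Within the data shown here, no measured step touches this position. Among the measured compounds shown here, the only step in hand, a 1.1-fold lower number from compound 1 to compound 2 (0.05 log units; within the scatter), alters the aryl group on the other end of the molecule and gives no guidance for the thiazole substituent, so neither direction can be argued from the data. The step is therefore expected to be a 1.3-fold higher number from compound 2 to compound 3 (0.11 log units; within the scatter), with a wide range to cover the absence of any precedent. Compound 3 is estimated at 12 ug/mL in this assay, between 4 ug/mL and 40 ug/mL.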

Compound 3, half-maximal inhibitory concentration: 30.2 ug/mL
The estimate for compound 3 lay 2.5-fold (0.40 log units) below the measured number, and the stated range covers the measured number.
By their numbers in this assay, from the lowest: compounds 2 and 1 (each within the scatter of the next); then compound 3.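

In this assay the group on the aromatic carbon next to the ring nitrogen matters: methyl in place of trifluoromethyl gives a 3.2-fold higher number from compound 2 to compound 3 (0.51 log units; beyond the scatter), a modest loss resting on this single pair. This is the only one of the two changes shown that passes the scatter, as the aryl change gave a 1.1-fold lower number from compound 1 to compound 2 (0.05 log units; within the scatter), so on these compounds the number responds more to this position than to where the trifluoromethyl sits on the phenyl ring. Nothing on hand explains the step.

From the compounds shown here alone, whether hydrogen, chlorine, ethyl or a cyclopropyl group on this carbon would keep the number near that of compound 2 remains open. Also open, going by these compounds, is whether methyl in place of trifluoromethyl gives a similar step when the far end carries the 3-(trifluoromethyl)phenyl group of compound 1.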